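The compounds below may be only part of what the source reports. "The series", "measured", "known", "first", "only" and "open" are said of these compounds alone.

In an ADME assay on L02 cells (Homo sapiens) for cytotoxicity, read by MTT assay, with a stated time of 24 h (on this read-out lower numbers stand for stronger inhibition and higher numbers for weaker inhibition), compound 1 `CN1C/C(=C\c2cccnc2)C(=O)/C(=C/c2cc([N+](=O)[O-])ccc2F)C1` gives 15700 nM, within the scatter of compound 2 `COc1ccc(/C=C2\CN(C)C/C(=C\c3ccncc3)C2=O)c(OC)c1OC` at 15600 nM. Compound 3 `CN1C/C(=C\c2ccncc2)C(=O)/C(=C/c2cc([N+](=O)[O-])ccc2F)C1` is still unmeasured. It differs from compound 1 by pyridin-4-yl in place of pyridin-3-yl on a double-bonded chain carbon bound to a double-bonded ring carbon, on a double-bonded chain carbon bound to a double-bonded ring carbon. For the measured compounds named here, no measured single-place step is available in this assay as a guide. Compound 2 also carries pyridin-4-yl and gives 15600 nM, on a different remaining structure, so no change beyond the scatter is expected. The estimated 1.0-fold lower number from compound 1 to compound 3 (0.02 log units; within the scatter) is expected to remain within the scatter. For compound 3 the estimated value is 15000 nM, with an expected range of 7500 nM to 30000 nM.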

Compound 3, half-maximal inhibitory concentration: 17600 nM
Compound 3: the middle estimate sits 1.2-fold (0.07 log units) below what was measured; the measured number falls inside the stated range.
By their numbers in this assay, from the lowest: compounds 2, 1 and 3 (each within the scatter of the next).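

In this assay, for the compounds shown here, pyridin-4-yl in place of pyridin-3-yl on a double-bonded chain carbon bound to a double-bonded ring carbon gives the first single-place step (a 1.1-fold higher number from compound 1 to compound 3 (0.05 log units; within the scatter)). On the core of compound 1, this exchange of the two pyridine isomers therefore leaves the number within the scatter. No supporting evidence bears on this result.

Still open, from the compounds shown here alone, is whether pyridin-2-yl, phenyl or a ring carrying a carboxylic acid at this place would go beyond the scatter. Also open, going by these compounds, is whether the same exchange stays within the scatter on the core of compound 2.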